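Chloro gives way to methoxy on the shared core

The source may hold more compounds than are shown below. What is called first, only, known or untested is meant among the compounds shown, and "the series" means these compounds.

Three compounds with a long fluorinated chain and a carboxy group have been followed in an ADME assay on a cell-free system (plasma, Mus musculus) for metabolic stability, tested at 5 uM; on this read-out lower numbers stand for a shorter-lived compound and higher numbers for a longer-lived compound. In this assay compound 1 `CNS(=O)(=O)c1cc(C(=O)O)ccc1NCCCCCCCC(F)(F)F` gives > 2 h, which is a limit and not a number. Compound 2 `O=C(O)c1ccc(NCCCCCCCC(F)(F)F)c(S(=O)(=O)N2CCCC2)c1` gives > 2 h, again a limit. Compound 3 `CN(C)S(=O)(=O)c1cc(C(=O)O)c(Cl)cc1NCCCCCCCC(F)(F)F` gives > 2 h, so it too stands only at a limit, with no exact half-life known.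

Compound 4 `COc1cc(NCCCCCCCC(F)(F)F)c(S(=O)(=O)N(C)C)cc1C(=O)O` is built like compound 3, with one change: methoxy in place of chloro on an aromatic carbon, ortho to a carboxy group and para to a dimethylsulfamoyl group (methoxy in place of chloro on an aromatic carbon).

Among the measured compounds shown here, the only measured step between close relatives is a step that the two limits leave unreadable from compound 1 to compound 2. It concerns pyrrolidin-1-yl in place of methylamino on a sulfonyl sulfur, a different change from this one, and it gives no size to carry over. The whole picture is the limit of > 2 h in this assay, at which 3 of the 3 values shown sit. For the measured compounds named here, no compound so far shows a short half-life, and no swap of chloro for methoxy has been measured. The estimated step is a step that the limit leaves unreadable from compound 3 to compound 4, and no shift beyond the usual scatter is expected in either direction. For compound 4 the expected half-life is 2.5 h, with an estimated range from 1.2 h to 5 h.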

Compound 4, half-life: > 2 h
Compound 4 was reported as a limit; the forecaster's own chance of this, stated with the estimate: 85%; the middle value does not contradict the limit.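

Compound 3 and compound 4 both stand only at a limit in this assay, so the swap of chloro for methoxy between them cannot be read as a step of any size. The compounds shown leave open how long each one actually lasts, and whether any change would give a short half-life: the limit of > 2 h in this assay, at which 4 of the 4 values shown sit.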